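The source may report more compounds than this note shows. Statements on the series, on what has been measured and on what is new or still open speak of the compounds shown alone.

Three compounds have been measured in a functional assay on HCT-116 cells (Homo sapiens) for inhibition, read by MTT assay, with a stated time of 72 h; a higher number here means a weaker inhibitor of growth, a lower number a stronger inhibitor of growth:
compound 1, `Cc1cc(CN2CCN(c3c(Br)cnc4[nH]c(N5CCN(Cn6cccn6)CC5)nc34)CC2)no1`, gives 120 nM
compound 2, `Cc1cc(CN2CCN(c3c(Br)cnc4[nH]c(-c5ccc(CN(C)C)cc5)nc34)CC2)no1`, gives 230 nM
compound 3, `COc1ccc(-c2nc3c(N4CCN(Cc5nccn5C)CC4)c(Br)cnc3[nH]2)cc1`, gives 1500 nM

Compound 1 has the lowest number of the three. Its nearest neighbour is compound 2, whose value lies within the usual scatter of compound 1, so the two cannot be told apart. Compound 3 lies furthest away, beyond the scatter, and is the weaker growth inhibitor of that pair.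

The unmeasured compound 4, `Cc1cc(CN2CCN(c3c(Cl)cnc4[nH]c(N5CCN(Cn6cccn6)CC5)nc34)CC2)no1`, differs from compound 1 in one place: chloro in place of bromo on an aromatic carbon. Within the data shown here, no measured pair shows this change directly, so no step can be read off. A swap of one halogen for another on the same aromatic carbon is expected to shift the value in this assay only a little, probably not beyond the scatter, perhaps slightly toward a weaker inhibitor. Compound 4 is therefore expected to give 180 nM, between 60 nM and 550 nM, an expected step of a 1.5-fold higher number from compound 1 to compound 4 (0.18 log units; within the scatter).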

Compound 4, concentration for 50% growth inhibition: 450 nM
Compound 4: middle estimate off by 2.5-fold (0.40 log units), on the low side; low and high end bracket the measured number.
By their numbers in this assay, from the lowest: compounds 1, 2 and 4 (each within the scatter of the next, the first and the last beyond it); then compound 3.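

In this assay, chloro in place of bromo on this aromatic carbon gives a 3.8-fold higher number from compound 1 to compound 4 (0.57 log units; beyond the scatter), so compound 4 is the weaker growth inhibitor of this pair and even one halogen for another matters at this position. The earlier compounds shown here all carry bromo here, so they could not show this sensitivity. Nothing available gives a reason for the shift.

The compounds shown leave open what fluoro, methyl or a plain hydrogen on this carbon would give. They also leave open whether the same swap moves the number as far in compound 2 or compound 3.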